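The source may hold more compounds than are shown below. What is called first, only, known or untested is meant among the compounds shown, and "the series" means these compounds.

In an ADME assay on MOLT-3 cells (Homo sapiens) for cytotoxicity, with a stated time of 7 days (a lower number here means that less compound is tolerated, a higher number that more compound is tolerated), compound 3 (`Nc1nc(NC2CCCCC2)c2ncn(/C=C3/CC3(CO)CO)c2n1`) gives "not determined" (no result reported), so the step starts from no number. Compound 3 carries cyclohexylamino, and compound 4 (`CCCOc1nc(N)nc2c1ncn2/C=C1/CC1(CO)CO`) differs from it as follows: propoxy in place of cyclohexylamino on an aromatic carbon. That is propoxy in place of cyclohexylamino on an aromatic carbon. The nearest measured neighbours of compound 4 are two other ethers on the same core. Compound 1 (`CCOc1nc(N)nc2c1ncn2/C=C1/CC1(CO)CO`) gives > 20000 nM, which is a limit of the assay and not a number. Compound 2 (`CCCCCCCCOc1nc(N)nc2c1ncn2/C=C1/CC1(CO)CO`) gives > 20000 nM, again a limit of the assay. For the measured compounds named here, the one measured step is a step that the two limits leave unreadable from compound 1 to compound 2, so it offers no size to carry over. What remains is the limit of > 20000 nM in this assay, at which 2 of the 3 values shown sit. The propoxy chain of compound 4 is longer than the chain of compound 1 and shorter than that of compound 2, so no step beyond the scatter is expected from these two in this assay, and a result at the same limit is likely. For compound 4 the estimated half-maximal cytotoxic concentration is 30000 nM, with an expected range of 12000 nM to 80000 nM.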

Compound 4, half-maximal cytotoxic concentration: > 20000 nM
Compound 4: only a limit was reported (the forecaster's own chance of this, stated with the estimate: 85%); the middle value lies beyond the limit too.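

For the compounds shown here, compound 1, compound 2 and compound 4 all give limits of the assay and not numbers in this assay, so no step among them can be read. The compounds shown leave open where the actual half-maximal cytotoxic concentration of any of these three lies.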